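Aryl piperazine sulfonamides: the iodophenyl step from compound 3

The source may report more compounds than this note shows. Statements on the series, on what has been measured and on what is new or still open speak of the compounds shown alone.

Compound 3 `CCCn1c(=O)[nH]c2nc(-c3ccc(S(=O)(=O)N4CCN(c5cccc(F)c5)CC4)cc3)[nH]c2c1=O` carries a 3-fluorophenyl on the ring nitrogen of the shared core. In an assay on CHO cells for displacement of a labelled ligand from adenosine receptor A1 (Homo sapiens), read by scintillation counting, with a stated time of 90 min, in the presence of a further agent that is not named here (on this read-out lower numbers stand for stronger inhibition and higher numbers for weaker inhibition), compound 3 gives > 1000 nM, which is a limit of the assay and not a number. Compound 1 `CCCn1c(=O)[nH]c2nc(-c3ccc(S(=O)(=O)N4CCN(c5ccccc5C)CC4)cc3)[nH]c2c1=O` gives 419 nM in this assay. Compound 2 `CCCn1c(=O)[nH]c2nc(-c3ccc(S(=O)(=O)N4CCN(c5cccc(Cl)c5)CC4)cc3)[nH]c2c1=O` gives > 1000 nM, again a limit. Both measured steps point the same way: an at least 2.3-fold higher number from compound 1 to compound 2 (0.37 log units; beyond the scatter) and an at least 2.3-fold higher number from compound 1 to compound 3 (0.37 log units; beyond the scatter); the pair a step that the two limits leave unreadable from compound 2 to compound 3. Compound 4 `CCCn1c(=O)[nH]c2nc(-c3ccc(S(=O)(=O)N4CCN(c5ccc(I)cc5)CC4)cc3)[nH]c2c1=O` differs from compound 3 by 4-iodophenyl in place of 3-fluorophenyl on an amine nitrogen in a ring. Within the data shown here, no measured step tests a 4-iodophenyl, so compound 2 and compound 3 sitting at the limit of > 1000 nM in this assay, at which 2 of the 3 values shown sit, form the only guide. Compound 4 is expected to stay near that limit, estimated at 1600 nM (range 500 nM to 6000 nM). The step that the limit leaves unreadable from compound 3 to compound 4 is therefore expected to fall within the scatter.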

Compound 4, inhibition constant: > 1000 nM
Compound 4 ended at the assay's limit; the forecaster's own chance of this, stated with the estimate: 65%; the middle value does not contradict the limit.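

In this assay compound 4 gives > 1000 nM as a limit of the assay and not a number. On the amine nitrogen in the ring, 4-iodophenyl thus joins 3-chlorophenyl and 3-fluorophenyl, leaving 2-methylphenyl as the only group shown with a readable value, and the one readable new step is an at least 2.3-fold higher number from compound 1 to compound 4 (0.37 log units; beyond the scatter). The steps among compound 2, compound 3 and compound 4 cannot be read, and the series now sits largely at one ceiling: the limit of > 1000 nM in this assay, at which 3 of the 4 values shown sit.

Going by these compounds, whether a 2-chlorophenyl or 2-methoxyphenyl on that nitrogen would also give a readable value remains open. So does any ranking of compound 2, compound 3 and compound 4.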